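A few compounds are considered here, and "the series" means these few. Any claim that something is new, unique, unknown or untested is made for them only; others in the source may bear on it.

Compound 1 `NCCCOc1ccc([C@H]2CC[C@]3(CC2)OOC2(O3)C3CC4CC(C3)CC2C4)cc1` is the starting point. In an ADME assay on microsomes from liver (Homo sapiens) for metabolic stability, read by LC-MS, tested at 1 uM (on this read-out higher numbers stand for fast clearance and lower numbers for slow clearance), compound 1 gives < 7 mL.min-1.g-1, a limit of the assay rather than a number. Compound 2 `c1cc([C@H]2CC[C@]3(CC2)OOC2(O3)C3CC4CC(C3)CC2C4)ccc1OCCOC1CCNCC1` likewise gives < 7 mL.min-1.g-1 in this assay, again a limit. Going by the values given here, compound 3 `c1cc([C@H]2CC[C@]3(CC2)OOC2(O3)C3CC4CC(C3)CC2C4)ccc1OC1CCNCC1` is the one member of the set with a measured number, 15 mL.min-1.g-1 in this assay. The step of an at least 2.1-fold higher number from compound 1 to compound 3 (0.33 log units; beyond the scatter) and the step of an at least 2.1-fold higher number from compound 2 to compound 3 (0.33 log units; beyond the scatter) both run in the same direction, while a step that the two limits leave unreadable from compound 1 to compound 2, since (the limit of < 7 mL.min-1.g-1 in this assay, at which 2 of the 3 values shown sit). Compound 1 therefore stands at the slow end of what has been seen so far, together with compound 2, with compound 3 the only one clearly faster.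

Compound 4 `NC1CCN(S(=O)(=O)c2ccc([C@H]3CC[C@]4(CC3)OOC3(O4)C4CC5CC(C4)CC3C5)cc2)CC1` has not been measured. It differs from compound 1 by (4-aminopiperidin-1-yl)sulfonyl in place of 3-aminopropoxy on an aromatic carbon. Among the compounds with values here, none of the measured steps involves a sulfonyl or a change at this ring carbon in the same way; the closest parallel is the move from an open aminoalkyl chain to a ring-borne amine in an at least 2.1-fold higher number from compound 1 to compound 3 (0.33 log units; beyond the scatter), which was at least modest and upward. Compound 4 is expected to show an at least 1.4-fold higher number from compound 1 to compound 4 (0.15 log units; that floor lies within the scatter) in this assay. For compound 4 the estimated value in this assay is 10 mL.min-1.g-1, within 4 mL.min-1.g-1 to 25 mL.min-1.g-1.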

Compound 4, intrinsic clearance in microsomes: < 7 mL.min-1.g-1
Compound 4: only a limit was reported (the forecaster's own chance of this, stated with the estimate: 35%); middle value at least 1.4-fold (0.15 log units) from the limit.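

In this assay, (4-aminopiperidin-1-yl)sulfonyl in place of (piperidin-4-yl)oxy on the aromatic carbon gives an at least 2.1-fold lower number from compound 3 to compound 4 (0.33 log units; beyond the scatter). Until now this position had carried only groups joined through an oxygen, and this result shows that a sulfonyl-linked group at the same carbon, para to a large group, can also sit at the slow end of the set. It also shows that a piperidine ring in the group does not by itself go with the higher number: compound 3 has such a ring and reads higher, whereas compound 2 and compound 4 also have one and do not. The steps from compound 1 and from compound 2 to compound 4 cannot be read, with limits on both sides, so compound 4 can only be grouped with those two compounds: the limit of < 7 mL.min-1.g-1 in this assay, at which 3 of the 4 values shown sit.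

From the compounds shown here alone, how compound 1, compound 2 and compound 4 rank beneath that shared limit remains open. Compound 3 and compound 4 also differ in both the linking atom and the place of the amine, so the two are not separated, and a piperidin-4-yl group joined through a sulfonyl, with its ring nitrogen free, would be needed to tell them apart.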